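A few compounds are considered here, and "the series" means these few. Any claim that something is new, unique, unknown or untested is made for them only; others in the source may bear on it.

Working notes on the anilino series sharing one core. Compound 1 `COc1cccc(NC2=CC(=O)c3c(nc4n3[C@H]3OC[C@@H](O)[C@H]3OC4)C2=O)c1` and compound 2 `O=C1C(Nc2cccc(Cl)c2)=CC(=O)c2c1nc1n2[C@H]2OC[C@@H](O)[C@H]2OC1` differ only in the group on the aromatic carbon. In a functional assay on MCF7 cells (Homo sapiens) for inhibition, read by sulforhodamine B assay (on this read-out higher numbers stand for weaker inhibition and lower numbers for stronger inhibition), compound 1 gives 3830 nM, and in this assay compound 2 gives 2970 nM. For the measured compounds named here, the one measured step, a 1.3-fold lower number from compound 1 to compound 2 (0.11 log units; within the scatter), is within the scatter, so the two values of compound 1 and compound 2 cannot be told apart on these numbers; compound 2 stands level with compound 1.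

Compound 3 `Cc1ccc(NC2=CC(=O)c3c(nc4n3[C@H]3OC[C@@H](O)[C@H]3OC4)C2=O)cc1C` is not yet measured. The change from compound 2 to compound 3 is 3,4-dimethylphenyl in place of 3-chlorophenyl on an amine nitrogen. Going by the values given here, the only step that bears on this change is the exchange on the same aromatic ring from compound 1 to compound 2, which stayed within the scatter, so no step beyond the scatter is expected for compound 3 in this assay, a 1.0-fold higher number from compound 2 to compound 3 (0.00 log units; within the scatter) being the expected step. Compound 3 is therefore estimated at 3000 nM in this assay, with a range from 1200 nM to 8000 nM.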

Compound 3, half-maximal inhibitory concentration: 4950 nM
Compound 3: the middle estimate sits 1.7-fold (0.22 log units) below what was measured, and the stated range covers the measured number.
By their numbers in this assay, from the lowest: compounds 2, 1 and 3 (each within the scatter of the next).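

In this assay, replacing either ring on the amine nitrogen with 3,4-dimethylphenyl extends the comparison to a different ring pattern, with 3-chlorophenyl giving way in one step (a 1.7-fold higher number from compound 2 to compound 3 (0.22 log units; within the scatter)) and 3-methoxyphenyl in the other (a 1.3-fold higher number from compound 1 to compound 3 (0.11 log units; within the scatter)). Both steps lie within the scatter, so the three compounds cannot be told apart, and 3,4-dimethylphenyl stands level with both rings it replaces at this position. Nothing at hand explains this level picture.

Still open is whether any group at this position can produce a step beyond the scatter, as only substituted phenyl rings are shown. A phenyl ring carrying a carboxylic acid or an amine, or a cyclohexyl ring on the same nitrogen, would test this.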